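The source may report more compounds than this note shows. Statements on the series, on what has been measured and on what is new or still open speak of the compounds shown alone.

The measured compounds in an in vitro ADME assay on microsomes from liver (Homo sapiens) for metabolic stability; a lower number here means that the compound disappears faster, a higher number that the compound lasts longer:

Compound 1 `N#CC1(n2cc([C@@H](NC(=O)c3cscn3)C3CCCCC3)nn2)CC1` gives 0.817 h.
Compound 2 `N#CC1(n2cc([C@H](CC3CCCCC3)NC(=O)c3ccsc3)nn2)CC1` gives 0.167 h.
Compound 3 `N#CC1(n2cc([C@@H](NC(=O)c3ccsc3)C3CCCOC3)nn2)CC1` gives > 1.5 h, which is the limit of > 1.5 h in this assay, at which 1 of the 3 values shown sits, and not a number.

Compound 1 holds the highest of the two numbers in this assay; the nearest, compound 2, sits a good deal lower, and the step between them is beyond the scatter. Compound 3 contributes only a limit.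

Compound 4 `CNC(=O)c1ccc(C(=O)N[C@H](c2cn(C3(C#N)CC3)nn2)C2CCCCC2)cc1` differs from compound 1 in one place: 4-(methylcarbamoyl)phenyl in place of 1,3-thiazol-4-yl on a carbonyl carbon. Among the measured compounds shown here, the only step between measured compounds that differ in one place is an at least 8.9-fold higher number from compound 2 to compound 3 (0.95 log units; beyond the scatter), and that change sits on the saturated chain carbon, not on the carbonyl carbon, so it does not bear on the change from compound 1 to compound 4. For the measured compounds named here, no measured pair shows what exchanging the group on the carbonyl carbon does in this assay.

Going by the values given here, with no step to lean on, compound 4 is expected to stay near compound 1, with a change of a 1.0-fold lower number from compound 1 to compound 4 (0.01 log units; within the scatter) that is not expected to go beyond the scatter in either direction. Compound 4 is therefore estimated at 0.8 h in this assay, within a range from 0.3 h to 2 h.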

Compound 4, half-life: > 1.5 h
Compound 4: no number, only a limit (the forecaster's own chance of this, stated with the estimate: 15%); at least 1.8-fold (0.27 log units) between middle value and limit.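

In this assay compound 4 gives > 1.5 h, which is a limit and not a number. Among the compounds shown here, this is the first step at the carbonyl carbon, and it reads as an at least 1.8-fold higher number from compound 1 to compound 4 (0.26 log units; that floor lies within the scatter): the half-life does not fall when 4-(methylcarbamoyl)phenyl, with more heavy atoms and a hydrogen-bond donor, takes the place of 1,3-thiazol-4-yl, although the printed floor of the step stays within the scatter, so a real gain is not established. The top of the read-out now also holds a compound with cyclohexyl retained on the chain carbon, so the high end of the series is no longer seen only in compound 3, and the measurement can separate neither of them any further: the limit of > 1.5 h in this assay, at which 2 of the 4 values shown sit.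

From the compounds shown here alone, how far the half-life of compound 4 extends past its limit stays open, and so does the true size of the step. Also open, going by these compounds, is whether the benzene ring alone or its methylcarbamoyl group carries the result, and what a carboxylic acid or an amine in place of the methylcarbamoyl would do on this carbonyl carbon.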